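This account rests on a few compounds, and the source may have more. Where it says the series, first, only, none or still open, it means among the compounds named here.

Measured in a functional assay (aorta) with Oryctolagus cuniculus as the target; a higher number here means weaker binding, a lower number tighter binding:
Compound 1 `COc1cc(C(C)O)ccc1OCCCN1CCC(C(c2ccc(F)cc2)c2ccc(F)cc2)CC1`: 10 nM
Compound 2 `CCc1ccc(OCCCN2CCC(C(c3ccc(F)cc3)c3ccc(F)cc3)CC2)c(OC)c1`: 2.51 nM
Compound 3 `COc1cc(C(=O)O)ccc1OCCCN1CCC(C(c2ccc(F)cc2)c2ccc(F)cc2)CC1`: 79.4 nM

Compound 3 has the highest number of the three, which makes it the weakest binder so far. Both of the steps that lead to it are beyond the scatter: a 7.9-fold higher number from compound 1 to compound 3 (0.90 log units; beyond the scatter) and a 32-fold higher number from compound 2 to compound 3 (1.50 log units; beyond the scatter).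

The next compound is compound 4 `CC(=O)c1ccc(OCCCN2CCC(C(c3ccc(F)cc3)c3ccc(F)cc3)CC2)cc1`. On an oxygen on a saturated carbon, 4-acetylphenyl stands in place of 4-carboxy-2-methoxyphenyl: 4-acetylphenyl in place of 4-carboxy-2-methoxyphenyl on an oxygen on a saturated carbon.

The two steps above bear most directly on this change, since each swaps carboxy for another group on an aromatic carbon. Read in reverse, both show that losing carboxy goes with a lower number, by a modest amount for the 1-hydroxyethyl of compound 1 and a large amount for the ethyl of compound 2. Acetyl is a different group from either, although a 4.0-fold lower number from compound 1 to compound 2 (0.60 log units; beyond the scatter) shows that this position can shift the number by a modest step. Among the measured compounds shown here, no measured compound lacks the methoxy, so that part of the change is untested.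

A modest to large drop is therefore expected, and the estimate is a 9.9-fold lower number from compound 3 to compound 4 (1.00 log units; beyond the scatter) in this assay. For compound 4 the expected value is 8 nM, with an estimated range of 2.5 nM to 30 nM.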

Compound 4, dissociation constant: 2.51 nM
Compound 4: the middle estimate sits 3.2-fold (0.50 log units) above what was measured; low and high end bracket the measured number.
By their numbers in this assay, from the lowest: compounds 2 and 4 (each within the scatter of the next); then compound 1; then compound 3.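

In this assay, replacing 4-carboxy-2-methoxyphenyl with 4-acetylphenyl on this oxygen gives a large drop (a 32-fold lower number from compound 3 to compound 4 (1.50 log units; beyond the scatter)), a modest drop when 4-(1-hydroxyethyl)-2-methoxyphenyl is replaced (a 4.0-fold lower number from compound 1 to compound 4 (0.60 log units; beyond the scatter)), and nothing beyond the scatter when 4-ethyl-2-methoxyphenyl is replaced (no change at the digits printed from compound 2 to compound 4 (within the scatter)). Among the compounds shown here, compound 4 is the first compound here without the methoxy, and it still matches the low number of compound 2, so a methoxy on this ring is not required to reach that level of binding in this small set. Each of these steps changes the group on the ring and removes the methoxy at once, so neither part can be credited alone, and no measurement shown here explains why the numbers move.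

A pair differing only in the methoxy, such as 4-acetyl-2-methoxyphenyl against 4-acetylphenyl, would separate those two parts. Also open, from the compounds shown here alone, is how an amine, an amide or a longer chain in place of the acetyl would behave at this place, and whether a carboxylic acid without the methoxy would still raise the number as far as in compound 3.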